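Sulfonamide series: lipophilicity of compounds 1 to 4

A few compounds are considered here, and "the series" means these few. Any claim that something is new, unique, unknown or untested is made for them only; others in the source may bear on it.

Measured so far in a physicochemical assay for lipophilicity, at pH 7.4; a lower number here means a more polar compound, a higher number a more lipophilic compound:
compound 1 `CC(C)CN(c1ccc(F)cc1F)S(=O)(=O)c1ccc2c(c1)C(=O)CC(C1CCOCC1)O2` gives 3.62
compound 2 `CCc1ccc(N(CC(C)C)S(=O)(=O)c2ccc3cc(OCC4CCOCC4)c(C(=O)OCC4CCOCC4)cc3c2)cc1` gives 6.34
compound 3 `CCc1ccc(N(CC(C)C)S(=O)(=O)c2ccc(OCC3CCOCC3)c3c2CCCC3=O)cc1` gives 4.84

Compound 1 holds the lowest of the three numbers in this assay. Compound 3 lies nearest, its number higher by a gap beyond the usual scatter; compound 2 lies furthest, higher again by a gap well beyond it. Going by the values given here, no two measured compounds differ in a single place, so no step within the measured set is known.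

Compound 4 `CC(C)CN(c1ccc(C#N)cc1)S(=O)(=O)c1ccc2c(c1)C(=O)CC(C1CCOCC1)O2` differs from compound 1 in one place: 4-cyanophenyl in place of 2,4-difluorophenyl on a sulfonamide nitrogen. Among the compounds with values here, no measured pair shows this change. For compound 4 a downward step is expected in this assay, beyond the scatter, amounting to a number 0.72 log units lower from compound 1 to compound 4 (beyond the scatter). The estimate for compound 4 in this assay is 2.9, with a range from 2.4 to 3.4.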

Compound 4, distribution coefficient: 3.16
Compound 4: the middle estimate sits 0.26 log units below what was measured; low and high end bracket the measured number.
By their numbers in this assay, from the lowest: compound 4; then compound 1; then compound 3; then compound 2.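

In this assay, 4-cyanophenyl in place of 2,4-difluorophenyl on a sulfonamide nitrogen gives a number 0.46 log units lower from compound 1 to compound 4 (beyond the scatter) with the rest of the structure unchanged. This is the series' one reading of a single change, and it shows that the number responds to the aryl group at this position. No measurement at hand accounts for the size of this step.

As far as these compounds go, how a plain phenyl on that nitrogen would stand remains open, and with it how much of the step belongs to the nitrile and how much to the two fluorines. From the compounds shown here alone, whether the same change carries over to other cores also remains open.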